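The compounds below may be only part of what the source reports. "The series", "measured", "known", "first", "only" and "open" are said of these compounds alone.

Working notes, series of three measured compounds and one pending.

Compound 1 `CCCCNC(=S)NC1=C(C#N)C(c2ccc(Cl)cc2Cl)C2=C(CCCC2=O)N1c1ccc(S(N)(=O)=O)cc1` gives 35% in a functional assay on Ehrlich cells (Mus musculus) for cytotoxicity, read by trypan blue exclusion, with a stated time of 2 h, tested at 50 ug/mL; a higher number here means a stronger effect of the compound at the concentration tested, a lower number a weaker effect. Compound 2 `C=CCNC(=S)NC1=C(C#N)C(c2ccc(Cl)cc2Cl)C2=C(CCCC2=O)N1c1ccc(S(N)(=O)=O)cc1` gives 33% in this assay, the lowest of the three numbers, with compound 1 nearest: the step of a number 2 percentage points lower from compound 1 to compound 2 (within the scatter). Compound 3 `N#CC1=C(NC(=O)CCC(=O)O)N(c2ccc(S(N)(=O)=O)cc2)C2=C(C(=O)CCC2)C1c1ccc(Cl)cc1Cl` gives 50% in this assay, furthest from compound 2.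

Compound 4 `N#CC1=C(N2C(=O)CCC2=O)N(c2ccc(S(N)(=O)=O)cc2)C2=C(C(=O)CCC2)C1c1ccc(Cl)cc1Cl` is to be measured in this assay. From compound 2 it differs thus: a group of 7 heavy atoms (4 carbon, 1 nitrogen, 2 oxygen; one five-membered non-aromatic ring with 1 hetero atom) in place of a group of 7 heavy atoms (4 carbon, 2 nitrogen, 1 sulfur; no ring), on a double-bonded ring carbon.

Among the measured compounds shown here, two measured steps bear on this change, both exchanging the thiourea-bearing group for a group of four carbon and three oxygen atoms on the same amine nitrogen: a number 15 percentage points higher from compound 1 to compound 3 (beyond the scatter) and a number 17 percentage points higher from compound 2 to compound 3 (beyond the scatter). In compound 4 the entering group also carries two oxygen atoms and two carbonyls, though closed into a five-membered ring and without hydrogen-bond donors. For the measured compounds named here, no measured pair shows a ring closure of this kind, so the expectation rests on the two steps to compound 3 alone, and a modest rise beyond the scatter is expected. For compound 4 the expected step is a number 12 percentage points higher from compound 2 to compound 4 (beyond the scatter). Compound 4 is therefore estimated at 45%, within 30% to 60%.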

Compound 4, a percentage reported as activity, at one concentration (the size of the read-out at that concentration, not a potency): 70%
For compound 4 the middle estimate is 25 percentage points below the measured one; the whole stated range lies below it.
By their numbers in this assay, from the lowest: compounds 2 and 1 (each within the scatter of the next); then compound 3; then compound 4.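

On the double-bonded ring carbon, 2,5-dioxopyrrolidin-1-yl gives the highest number of the series in this assay, with a number 37 percentage points higher from compound 2 to compound 4 (beyond the scatter) and a number 35 percentage points higher from compound 1 to compound 4 (beyond the scatter), so the thiourea-bearing groups can be exchanged for a closed ring with a large gain. The ring also surpasses the open acid chain, with a number 20 percentage points higher from compound 3 to compound 4 (beyond the scatter), which shows that the carboxylic acid and the hydrogen-bond donors of compound 3 are not needed for a high number at this position. Nothing at hand accounts for the size of these steps.

Open, as far as these compounds go, is whether ring size matters, as a six-membered 2,6-dioxopiperidin-1-yl would show. Also open, from the compounds shown here alone, is whether a simple acetamide at this position would stand nearer compound 3 or compound 4, which would separate the effect of ring closure from that of the acid.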